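This account rests on a few compounds, and the source may have more. Where it says the series, first, only, none or still open, it means among the compounds named here.

Measured so far in an ADME assay on MT4 cells (Homo sapiens) for cytotoxicity, read by MTT assay, with a stated time of 96 h; a higher number here means that more compound is tolerated, a lower number that less compound is tolerated:
compound 1 `C/C(=N\NC(N)=S)c1ccc2c(c1)nc(-c1ccc(C(F)(F)F)cc1)n2C1CCCCC1` at 30000 nM
compound 2 `COc1ccc(-c2nc3cc(/C(C)=N/NC(N)=S)ccc3n2C2CCCCC2)c(OC)c1` at 17000 nM

Compound 2 stands within the scatter of compound 1 on these two numbers. The change to compound 3 `C/C(=N\NC(N)=S)c1ccc2c(c1)nc(-c1ccoc1)n2C1CCCCC1` is furan-3-yl in place of 2,4-dimethoxyphenyl on an aromatic carbon and leaves the rest of the structure untouched, so a five-membered aromatic ring with 1 hetero atom replaces one six-membered aromatic ring of carbon only. Among the compounds with values here, only one measured step bears on this carbon, and a 1.8-fold lower number from compound 1 to compound 2 (0.25 log units; within the scatter) is what it gave, so no step beyond the scatter is expected in this assay here. Within the data shown here, no furan-3-yl compound has been measured. The expected move is a 1.5-fold higher number from compound 2 to compound 3 (0.17 log units; within the scatter) in this estimate. Compound 3 is estimated at 25000 nM with a range of 10000 nM to 60000 nM as expected bounds.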

Compound 3, half-maximal cytotoxic concentration: 21000 nM
Compound 3: middle estimate off by 1.2-fold (0.08 log units), on the high side; the measured number falls inside the stated range.
By their numbers in this assay, from the lowest: compounds 2, 3 and 1 (each within the scatter of the next).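

At the aromatic carbon between two ring nitrogen atoms, this assay now covers a five-membered aromatic ring as well as six-membered aromatic rings of carbon only. Furan-3-yl gives a 1.2-fold higher number from compound 2 to compound 3 (0.09 log units; within the scatter) and a 1.4-fold lower number from compound 1 to compound 3 (0.15 log units; within the scatter) and so stays within the scatter of both, even though the group has fewer heavy atoms than 2,4-dimethoxyphenyl. No measured evidence bears on why these numbers stay so close.

From the compounds shown here alone, whether this carbon tolerates an amine or a carboxylic acid as well remains open. The same holds for a non-aromatic group such as a longer alkyl chain.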